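Alkoxy chain variation in the shared core

The source may report more compounds than this note shows. Statements on the series, on what has been measured and on what is new or still open speak of the compounds shown alone.

Compound 3 `C=CCc1cc(OC)c(OC(C)C(OCCCCCC)c2ccc(O)c(OC)c2)c(OC)c1` gives 329 nM in an assay on HEK293 cells for agonist activity at transient receptor potential cation channel subfamily M member 8 (Homo sapiens), read by fluorescence and calcium flux, with a stated time of 5 min (a higher number here means that more compound is needed for the effect, a lower number that less compound is needed), the lowest number of the three shown, though compound 1 `C=CCc1cc(OC)c(OC(C)C(OCC)c2ccc(O)c(OC)c2)c(OC)c1` with 332 nM stands within the scatter of it and is not separated from it. Compound 2 `C=CCc1cc(OC)c(OC(C)C(OC)c2ccc(O)c(OC)c2)c(OC)c1` gives 3450 nM, the furthest away, with a 10-fold lower number from compound 2 to compound 3 (1.02 log units; beyond the scatter). Compound 4 `C=CCc1cc(OC)c(OC(C)C(OCC(C)C)c2ccc(O)c(OC)c2)c(OC)c1` differs from compound 3 by isopropyl in place of pentyl on a saturated chain carbon bound to an oxygen on a saturated carbon. The steps bearing on this are a 1.0-fold lower number from compound 1 to compound 3 (0.00 log units; within the scatter) and a 10-fold lower number from compound 2 to compound 3 (1.02 log units; beyond the scatter): only the shortest group, in compound 2, stands apart, while compound 1 and compound 3 agree. Isopropyl is longer than methyl and shorter than pentyl, so no step beyond the scatter is expected, a 1.1-fold higher number from compound 3 to compound 4 (0.03 log units; within the scatter). Compound 4 is therefore estimated at 350 nM, with a range of 150 nM to 800 nM.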

Compound 4, half-maximal effective concentration: 138 nM
Compound 4: middle estimate off by 2.5-fold (0.40 log units), on the high side; the measured number lies below the stated range.
By their numbers in this assay, from the lowest: compound 4; then compounds 3 and 1 (each within the scatter of the next); then compound 2.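

The branched isopropyl group separates itself at this position, on a saturated chain carbon bound to an oxygen on a saturated carbon, where the unbranched pentyl group and the methyl group of compound 1 had not separated in this assay: a 2.4-fold lower number from compound 3 to compound 4 (0.38 log units; beyond the scatter) and a 2.4-fold lower number from compound 1 to compound 4 (0.38 log units; beyond the scatter). The distance from the shortest group also widens, with a 25-fold lower number from compound 2 to compound 4 (1.40 log units; beyond the scatter), so the number does not follow chain size alone, and compound 3 goes against such a trend. No supporting evidence bears on this result. An unbranched propyl group would help show whether branching or chain size matters here. Going by these compounds, a tert-butyl group or a terminal amine on the chain also remains open.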